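The source may hold more compounds than are shown below. What is called first, only, known or untested is meant among the compounds shown, and "the series" means these compounds.

In a functional assay on MCF7 cells (Homo sapiens) for cytotoxicity, read by MTT assay, with a stated time of 72 h (a higher number here means a weaker inhibitor, a lower number a stronger inhibitor), two compounds of this series have been measured so far. Compound 1 `CN(C)c1ccc(C=C2C(=O)N(c3ccc(Cl)cc3)N(c3ccc(Cl)cc3)C2=O)cc1` gives > 128000 nM, which is a limit of the assay and not a number. Among the measured compounds shown here, compound 2 `O=C1C(=Cc2ccc(F)cc2)C(=O)N(c2ccc(Cl)cc2)N1c1ccc(Cl)cc1` gives 31400 nM, the only true number available, so it cannot yet be ranked against any other exact value. Fluoro in place of dimethylamino on an aromatic carbon gives an at least 4.0-fold lower number from compound 1 to compound 2 (0.61 log units; beyond the scatter), and the size of that step is open-ended, as the limit of > 128000 nM in this assay, at which 1 of the 2 values shown sits, shows.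

Compound 3 `O=C1C(=Cc2ccc(Cl)cc2)C(=O)N(c2ccc(Cl)cc2)N1c1ccc(Cl)cc1` has chloro in place of fluoro on an aromatic carbon, para to a large group: chloro in place of fluoro on an aromatic carbon. The same difference can be read as 4-fluorophenyl to 4-chlorophenyl. For the measured compounds named here, only the step to compound 2 31400 nM touches this position, and it exchanged dimethylamino for a halogen, so it does not compare one halogen with another. No step beyond the scatter is therefore expected in this assay, and the expected change is a 1.3-fold lower number from compound 2 to compound 3 (0.10 log units; within the scatter). For compound 3 the estimated value is 25000 nM, with an expected range of 10000 nM to 65000 nM.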

Compound 3, half-maximal inhibitory concentration: 28500 nM
Estimate against measurement, compound 3: 1.1-fold (0.06 log units) below; the measured number falls inside the stated range.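

In this assay, exchanging one halogen for another on an aromatic carbon, para to a large group, gives a 1.1-fold lower number from compound 2 to compound 3 (0.04 log units; within the scatter), so 4-fluorophenyl and 4-chlorophenyl cannot be told apart here. The earlier compounds shown here compared only fluoro with dimethylamino at this position; chloro in place of dimethylamino now gives an at least 4.4-fold lower number from compound 1 to compound 3 (0.65 log units; beyond the scatter), so the step away from dimethylamino recurs with a second halogen and does not depend on fluoro alone. The size of this step stays open-ended, as the value of compound 1 is a limit of the assay and not a number: the limit of > 128000 nM in this assay, at which 1 of the 3 values shown sits.

As far as these compounds go, what a bromo, methoxy or nitrile group at this position would give remains open, as does whether a plain hydrogen would match compound 2 and compound 3 or move away from them. The two 4-chlorophenyl groups on the shared core are the same in all the compounds shown, so the effect of another group there, such as an unsubstituted phenyl, is also open.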